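This account rests on a few compounds, and the source may have more. Where it says the series, first, only, none or still open, it means among the compounds named here.

In an assay on mitochondria from L6 cells (Rattus norvegicus) for activation, with a stated time of 90 min (on this read-out lower numbers stand for an effect already at smaller amounts and higher numbers for an effect only at larger amounts of compound), compound 1, `CCCCOc1cccc(Nc2nc3nonc3nc2O)c1`, gives 2300 nM. That is the lowest of the two numbers recorded here. The closest neighbour is compound 3, `Oc1nc2nonc2nc1Nc1ccc(F)cc1`, which in this assay gives 38600 nM, a gap that lies beyond the usual scatter of repeated measurements. Compound 2, `Cc1cccc(C)c1Nc1nc2nonc2nc1O`, reaches only a limit in this assay, > 100000 nM, and so contributes no number; it is the one case of the limit of > 100000 nM in this assay, at which 1 of the 3 values shown sits.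

Compound 4, `Oc1nc2nonc2nc1Nc1cccc(C(F)(F)F)c1`, has not yet been measured in this assay. It differs from compound 1 in one place: trifluoromethyl in place of butoxy on an aromatic carbon. Within the data shown here, no pair of measured compounds shows this particular exchange, so its effect has to be estimated rather than read off. Because compound 1 gives 2300 nM while compound 3 gives 38600 nM, the shared core tolerates some variation on the aryl ring without losing all effect, and the trifluoromethyl group is expected to shift the number only moderately. The step from compound 1 to compound 4 is expected to be a 2.6-fold higher number from compound 1 to compound 4 (0.42 log units; beyond the scatter), a modest rise. Compound 4 is therefore estimated to give 6000 nM in this assay, with a likely range from 1500 nM to 25000 nM.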

Compound 4, half-maximal effective concentration: 13300 nM
Compound 4: the middle estimate sits 2.2-fold (0.35 log units) below what was measured, within the range that was stated.
By their numbers in this assay, from the lowest: compound 1; then compound 4; then compound 3. At a limit, above all of these: compound 2.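

Among these compounds, replacing butoxy with trifluoromethyl on this aromatic carbon gives a 5.8-fold higher number from compound 1 to compound 4 (0.76 log units; beyond the scatter), the first change at a single place that can be read directly in this assay. The step is modest, and compound 4 still gives a number, 13300 nM, rather than a limit, so on this shared core the butoxy chain can be exchanged for a group with fewer heavy atoms and no hydrogen-bond acceptor while a measurable effect remains. No measured property shown here bears on why the number rises, and this single step cannot separate the loss of the chain and its oxygen from the arrival of the fluorine atoms.

From the compounds shown here alone, what a methoxy group or a longer chain such as hexyloxy would give on this carbon remains open, and with it whether the length of the chain or its oxygen goes with the lower number of compound 1. Going by these compounds, how an amine or a carboxylic acid would compare at the same place is also open, as is whether this exchange would have a similar effect on another aromatic carbon.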